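Isopropoxy Gives Way to Trifluoromethoxy in Compound 4

A few compounds are considered here, and "the series" means these few. Any claim that something is new, unique, unknown or untested is made for them only; others in the source may bear on it.

Compound 3 `CC#C[C@@H](CC(=O)O)c1ccc(OC[C@H]2COc3ccc(OC(C)C)cc3O2)cc1` gives 90% in a functional assay on HEK293 cells for agonist activity at Free fatty acid receptor 1 (Homo sapiens), read by fluorescence and calcium flux, with a stated time of 10 min (on this read-out higher numbers stand for larger maximal responses and lower numbers for smaller maximal responses), the highest of the three values measured. Compound 2 `CC#C[C@@H](CC(=O)O)c1ccc(OC[C@H]2COc3ccc(C)cc3O2)cc1` gives 78% and compound 1 `CC#C[C@@H](CC(=O)O)c1ccc(OC[C@H]2COc3ccccc3O2)cc1` gives 70%; the steps of a number 20 percentage points higher from compound 1 to compound 3 (beyond the scatter) and a number 12 percentage points higher from compound 2 to compound 3 (beyond the scatter) lie beyond the scatter, while a number 8 percentage points higher from compound 1 to compound 2 (within the scatter) stays within it. Compound 4 `CC#C[C@@H](CC(=O)O)c1ccc(OC[C@H]2COc3ccc(OC(F)(F)F)cc3O2)cc1` differs from compound 3 in a single place: trifluoromethyl in place of isopropyl on an oxygen on an aromatic ring. Within the data shown here, no measured step covers this exchange directly; the only bearing comes from the two steps into compound 3, which show that changing the group at this aromatic carbon has moved the maximal response only modestly. The step of a number 5 percentage points lower from compound 3 to compound 4 (within the scatter) is therefore expected to stay small, likely within the scatter. Compound 4 is estimated at 85%, with a range from 72% to 98%.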

Compound 4, largest response reached (Emax), in percent of the reference or control that the assay uses: 73%
Estimate against measurement, compound 4: 12 percentage points above; the range from low to high includes it.
By their numbers in this assay, from the lowest: compounds 1, 4 and 2 (each within the scatter of the next); then compound 3.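

In this assay the step of a number 17 percentage points lower from compound 3 to compound 4 (beyond the scatter) shows that an oxygen on the aromatic ring does not by itself carry the higher maximal response of compound 3; what sits on that oxygen counts. With trifluoromethyl on that oxygen, the steps of a number 5 percentage points lower from compound 2 to compound 4 (within the scatter) and a number 3 percentage points higher from compound 1 to compound 4 (within the scatter) place the number level with those of the methyl and hydrogen compounds. Nothing at hand accounts for this drop. On these data alone, whether ethoxy or a longer alkoxy chain on this aromatic carbon would hold the response of compound 3 stays open, and so does what an amine there would give.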